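The source may report more compounds than this note shows. Statements on the series, on what has been measured and on what is new or still open speak of the compounds shown alone.

Measured compounds:
compound 1 `CCN(CC)Cc1ccc2nc(NC(=O)N/N=C/c3c[nH]c4ccccc34)sc2c1`: 1900 nM
compound 2 `CN(C)Cc1ccc2nc(NC(=O)N/N=C/c3c[nH]c4ccccc34)sc2c1`: 1190 nM

Both were run in a functional assay on MDA-MB-231 cells (Homo sapiens) for cytotoxicity, read by MTT assay, with a stated time of 72 h; on this read-out lower numbers stand for stronger inhibition and higher numbers for weaker inhibition. In this assay compound 1 gives the highest of the two numbers; its nearest neighbour is compound 2, and the step of a 1.6-fold lower number from compound 1 to compound 2 (0.20 log units; within the scatter) is within the scatter, so the two compounds are not separated on this read-out.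

Compound 3 `CCN(CC)Cc1ccc2nc(NC(=O)N/N=C/c3cn(Cc4ccc(C(C)(C)C)cc4)c4ccccc34)sc2c1` has not been measured. It differs from compound 1 by 4-(tert-butyl)benzyl in place of hydrogen on an aromatic nitrogen. For the measured compounds named here, the single measured step, a 1.6-fold lower number from compound 1 to compound 2 (0.20 log units; within the scatter), concerns the amine on the saturated chain carbon bound to an aromatic carbon and leaves the aromatic nitrogen untouched, so it gives no direct guidance on the present change. Going by the values given here, no measured pair shows what the entering 4-(tert-butyl)benzyl group on the aromatic nitrogen does in this assay. With nothing to anchor a direction, compound 3 is expected to stay near compound 1, and the expected step is a 1.1-fold lower number from compound 1 to compound 3 (0.05 log units; within the scatter), with a wide range either way. For compound 3 the estimated value in this assay is 1700 nM, in the range 450 nM to 6500 nM.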

Compound 3, half-maximal inhibitory concentration: 2120 nM
Beside the measured number, compound 3's estimate is 1.2-fold (0.10 log units) below it, and the stated range covers the measured number.
By their numbers in this assay, from the lowest: compounds 2, 1 and 3 (each within the scatter of the next).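

On the aromatic nitrogen of the five-membered aromatic ring, 4-(tert-butyl)benzyl in place of hydrogen brings in 11 heavy atoms and one six-membered aromatic ring of carbon only, yet in this assay the pair does not separate (a 1.1-fold higher number from compound 1 to compound 3 (0.05 log units; within the scatter)). For the compounds shown here, the earlier pair spoke only to the amine on the saturated chain carbon, whereas this pair gives the one reading at the aromatic nitrogen: here, a group of this count of heavy atoms leaves the number within the scatter of the unsubstituted compound. Nothing available on these compounds accounts for this result.

The compounds shown leave open whether a methyl group, an unsubstituted benzyl, or a benzyl carrying a carboxylic acid or an amine on this aromatic nitrogen would give a step beyond the scatter. Also open, as far as these compounds go, is whether 4-(tert-butyl)benzyl at this position reads the same when dimethylamino replaces diethylamino on the saturated chain carbon.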